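The source may hold more compounds than are shown below. What is called first, only, known or untested is meant among the compounds shown, and "the series" means these compounds.

Measured compounds:
Compound 1 `COc1ccc(OC)c(-c2cc(-c3ccccc3)nn2-c2ccc(S(N)(=O)=O)cc2)c1` gives 12300 nM in a functional assay on cells (Cancer cell lines, Homo sapiens) for cytotoxicity, read by sulforhodamine B assay, with a stated time of 48 h; on this read-out lower numbers stand for stronger inhibition of growth and higher numbers for weaker inhibition of growth.
Compound 2 `COc1ccc(OC)c(-c2cc(-c3ccccc3)nn2-c2ccc(S(=O)(=O)NC(C)=O)cc2)c1` gives 9700 nM in this assay.
Compound 3 `COc1ccc(OC)c(-c2cc(-c3ccc(Cl)cc3)nn2-c2ccc(S(=O)(=O)NC(C)=O)cc2)c1` gives 25500 nM in this assay.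

Compound 2 stands lowest of the three numbers: compound 1 is close to it, by a 1.3-fold lower number from compound 1 to compound 2 (0.10 log units; within the scatter), while compound 3 lies further off, by a 2.6-fold higher number from compound 2 to compound 3 (0.42 log units; beyond the scatter). Compound 4 `CC(=O)NS(=O)(=O)c1ccc(-n2nc(-c3ccccc3)cc2C2=CC(=O)C=CC2=O)cc1` differs from compound 2 by a group of 8 heavy atoms (6 carbon, 2 oxygen; one six-membered non-aromatic ring of carbon only) in place of a group of 10 heavy atoms (8 carbon, 2 oxygen; one six-membered aromatic ring of carbon only), on an aromatic carbon. Neither measured step touches this group: one changed the sulfonamide nitrogen, the other added a chloro group on an aromatic carbon. Among the compounds with values here, there is thus no direct precedent, and the expectation can only be loose. Compound 4 is estimated to fall near 8000 nM in this assay, between 1500 nM and 40000 nM, which as a step means a 1.2-fold lower number from compound 2 to compound 4 (0.08 log units; within the scatter) and is expected to lie within the scatter.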

Compound 4, concentration for 50% growth inhibition: 78500 nM
The estimate for compound 4 lay 9.8-fold (0.99 log units) below the measured number; measured number outside the range, above it.
By their numbers in this assay, from the lowest: compounds 2 and 1 (each within the scatter of the next); then compound 3; then compound 4.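

In this assay, the aromatic carbon bearing the 2,5-dimethoxyphenyl group proves sensitive to change: putting the non-aromatic six-membered carbon ring there gives an 8.1-fold higher number from compound 2 to compound 4 (0.91 log units; beyond the scatter). Within the data shown here, the earlier steps changed other places, so this is the first sign that the group on this carbon matters for inhibition of growth. No measurement shown accounts for this step. The compounds shown cannot separate losing the 2,5-dimethoxyphenyl group from gaining the new ring. On these data alone, how a plain phenyl, a 2,5-dihydroxyphenyl or an amine on this carbon would compare remains open.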